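From allyl to carboxymethyl: one change, no measured step

A few compounds are considered here, and "the series" means these few. Any claim that something is new, unique, unknown or untested is made for them only; others in the source may bear on it.

Of the compounds shown here, three have been measured in a functional assay on the whole organism with Rattus norvegicus as the target (a lower number here means that less compound is needed, a higher number that more compound is needed for the effect), so far. Compound 1 (`C[Si](C)(C)c1ccc2nc(N)sc2c1`) gives 5 mg/kg and compound 2 (`Nc1nc2ccc(OCC(F)(F)C(F)(F)F)cc2s1`) gives 7.5 mg/kg on this read-out. Compound 3 (`C=CCn1c(=N)sc2cc(OC(F)(F)F)ccc21`) gives 7 mg/kg and stands within the usual scatter of both compound 1 and compound 2, so the numbers do not separate the three.

Compound 4 (`N=c1sc2cc(OC(F)(F)F)ccc2n1CC(=O)O`) differs from compound 3 in one place: carboxy in place of vinyl on a saturated chain carbon bound to an aromatic nitrogen (carboxy in place of vinyl on a saturated chain carbon bound to an aromatic nitrogen, or, cut one bond further out, allyl to carboxymethyl). Within the data shown here, no two measured compounds differ in a single place, so no measured step can serve as a guide. None of the three measured compounds carries a carboxy group either, which leaves the expectation resting on the structural change alone and makes it uncertain. A moderate move towards a higher number, meaning that more compound is needed, is expected, and the estimate amounts to a 2.6-fold higher number from compound 3 to compound 4 (0.41 log units; beyond the scatter) in that direction. In this assay the expected value for compound 4 is 18 mg/kg (6 mg/kg to 55 mg/kg).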

Compound 4, dose for half-maximal effect: > 10 mg/kg
Compound 4: only a limit was reported (the forecaster's own chance of this, stated with the estimate: 25%); the middle value lies beyond the limit too.
By their numbers in this assay, from the lowest: compounds 1, 3 and 2 (each within the scatter of the next). At a limit, above all of these: compound 4.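

Among these compounds, this is the first measured step at this place, on a saturated chain carbon bound to an aromatic nitrogen: in this assay, carboxy in place of vinyl gives an at least 1.4-fold higher number from compound 3 to compound 4 (0.15 log units; that floor lies within the scatter). Compound 4 therefore carries a limit of the assay and not a number: the limit of > 10 mg/kg in this assay, at which 1 of the 4 values shown sits. The change from allyl to carboxymethyl places compound 4 at that limit, past the numbers of the other three compounds in the order of this assay, yet the floor of the step alone does not separate compound 4 from compound 3 beyond the scatter, so the step shows a direction but not a size.

As far as these compounds go, how far compound 4 actually lies from compound 3 stays open, since the limit gives no number to set against the value of compound 3. The compounds shown also leave open whether an ester or an amide of the carboxymethyl group, a longer chain ending in a carboxylic acid, or an amine in the place of the carboxy group would read like compound 3 or like compound 4 in this assay.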